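Sulfonyl substituent series: replacing the amine sulfonamide with a sulfone

This account rests on a few compounds, and the source may have more. Where it says the series, first, only, none or still open, it means among the compounds named here.

Of the compounds shown here, three on the shared core have been measured in an assay on CHO cells for displacement of a labelled ligand from prostaglandin D2 receptor 2 (Homo sapiens), read by scintillation counting; a lower number here means a stronger inhibitor, a higher number a weaker inhibitor. Compound 1 `COCCNS(=O)(=O)c1ccc(C)c(C#Cc2cc(Cl)ccc2OCC(=O)O)c1` gives 3.6 nM. Compound 2 `Cc1ccc(S(=O)(=O)N(C)CCCN(C)C)cc1C#Cc1cc(Cl)ccc1OCC(=O)O` gives 287 nM, and compound 3 `Cc1ccc(S(=O)(=O)N(C)CCN(C)C)cc1C#Cc1cc(Cl)ccc1OCC(=O)O` gives 369 nM. Compound 3 carries the highest of the three numbers; its nearest neighbour is compound 2, with a 1.3-fold higher number from compound 2 to compound 3 (0.11 log units; within the scatter) between them, while compound 1 lies furthest off, with a 100-fold higher number from compound 1 to compound 3 (2.01 log units; beyond the scatter).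

The next compound, compound 4 `Cc1ccc(S(=O)(=O)CC(C)C)cc1C#Cc1cc(Cl)ccc1OCC(=O)O`, differs from compound 3 in one place: isobutyl in place of (2-(dimethylamino)ethyl)(methyl)amino on a sulfonyl sulfur.

Going by the values given here, the steps that bear on this are the two in which (2-methoxyethyl)amino stands against a chain carrying dimethylamino: an 80-fold higher number from compound 1 to compound 2 (1.90 log units; beyond the scatter) and a 100-fold higher number from compound 1 to compound 3 (2.01 log units; beyond the scatter), both large. The step of a 1.3-fold higher number from compound 2 to compound 3 (0.11 log units; within the scatter) shows that the two dimethylamino-carrying chains are indistinguishable within the scatter. Compound 4 removes the dimethylamino-carrying chain altogether, so a large step back toward the number of compound 1 is expected. Compound 4 is estimated at 10 nM, between 2 nM and 60 nM, which corresponds to an expected step of a 37-fold lower number from compound 3 to compound 4 (1.57 log units; beyond the scatter). Whether isobutyl on the sulfonyl sulfur fully matches (2-methoxyethyl)amino there is not settled by the three measured compounds, so the range is kept wide.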

Compound 4, inhibition constant: 3 nM
Compound 4: the middle estimate sits 3.3-fold (0.52 log units) above what was measured, and the stated range covers the measured number.
By their numbers in this assay, from the lowest: compounds 4 and 1 (each within the scatter of the next); then compounds 2 and 3 (each within the scatter of the next).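

In this assay the sulfonyl sulfur does not depend on an attached amine: a 1.2-fold lower number from compound 1 to compound 4 (0.08 log units; within the scatter) lies within the scatter, so isobutyl and (2-methoxyethyl)amino cannot be told apart at this position. Set against the two chains carrying dimethylamino, the same isobutyl group gives large steps of similar reach, a 120-fold lower number from compound 3 to compound 4 (2.09 log units; beyond the scatter) and a 96-fold lower number from compound 2 to compound 4 (1.98 log units; beyond the scatter), which places the high numbers of compound 2 and compound 3 with those substituents and not with the sulfonyl position as such. Nothing available here accounts for any of these steps.

Compound 2 and compound 3 differ from compound 1 both in the dimethylamino end and in the extra methyl on the sulfonamide nitrogen, so the shown compounds cannot assign the loss to either feature; (2-methoxyethyl)(methyl)amino on the sulfonyl sulfur would separate the two. As far as these compounds go, it also remains open how far the sulfur tolerates other carbon groups, such as a longer chain than isobutyl or a chain ending in a carboxylic acid.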